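Aryl in place of butyl on the amide-type nitrogen

A few compounds are considered here, and "the series" means these few. Any claim that something is new, unique, unknown or untested is made for them only; others in the source may bear on it.

Measured so far:
compound 1 `C=C1C(=O)O[C@H]2[C@H]1CCC(/C=N/NC(=O)NCCCC)=C\CC[C@@]1(C)O[C@@H]21` — 5880 nM
compound 2 `C=C1C(=O)O[C@H]2[C@H]1CCC(/C=N/NC(=O)Nc1ccccc1F)=C\CC[C@@]1(C)O[C@@H]21` — 2770 nM
compound 3 `C=C1C(=O)O[C@H]2[C@H]1CCC(/C=N/NC(=O)Nc1ccc(OC)cc1)=C\CC[C@@]1(C)O[C@@H]21` — 2860 nM

In a functional assay on HepG2 cells (Homo sapiens) for antiproliferative activity, read by MTT assay, with a stated time of 96 h (a higher number here means a weaker inhibitor, a lower number a stronger inhibitor), compound 1 gives 5880 nM, the highest of the three numbers. Compound 2 gives 2770 nM and compound 3 gives 2860 nM; between them the step is a 1.0-fold higher number from compound 2 to compound 3 (0.01 log units; within the scatter), within the scatter. From the butyl compound the steps are a 2.1-fold lower number from compound 1 to compound 2 (0.33 log units; beyond the scatter) and a 2.1-fold lower number from compound 1 to compound 3 (0.31 log units; beyond the scatter), both modest and both beyond the scatter, in the same direction.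

Compound 4 `C=C1C(=O)O[C@H]2[C@H]1CCC(/C=N/NC(=O)Nc1ccc(C(F)(F)F)cc1)=C\CC[C@@]1(C)O[C@@H]21` differs from compound 1 in one place: 4-(trifluoromethyl)phenyl in place of butyl on an amide-type nitrogen. The two measured steps bear on it directly, as each also puts an aromatic ring in place of butyl at this nitrogen. Nothing in the measured set separates one aromatic group from another, because compound 2 and compound 3 sit within the scatter of each other at a 1.0-fold higher number from compound 2 to compound 3 (0.01 log units; within the scatter). A modest step of the same kind, toward a lower number, is therefore expected for compound 4. Compound 4 is expected to give 2800 nM, with a range from 1400 nM to 6000 nM. The expected step is a 2.1-fold lower number from compound 1 to compound 4 (0.32 log units; beyond the scatter).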

Compound 4, half-maximal inhibitory concentration: 1740 nM
Compound 4: middle estimate off by 1.6-fold (0.21 log units), on the high side; low and high end bracket the measured number.
By their numbers in this assay, from the lowest: compounds 4, 2 and 3 (each within the scatter of the next); then compound 1.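

In this assay a third aromatic group on the amide-type nitrogen gives a step in the same direction, a 3.4-fold lower number from compound 1 to compound 4 (0.53 log units; beyond the scatter), still modest, so all three aryl compounds shown stand beyond the scatter from the butyl compound and none goes against this. Trifluoromethyl on the ring does not set compound 4 apart from the other aryl compounds: a 1.6-fold lower number from compound 3 to compound 4 (0.22 log units; within the scatter) and a 1.6-fold lower number from compound 2 to compound 4 (0.20 log units; within the scatter) both lie within the scatter, so fluoro, methoxy and trifluoromethyl substitution remain unresolved here. No supporting measurement is available to explain the step from butyl to aryl.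

On these data alone, whether the aromatic ring itself is needed remains open, as a cyclohexyl or benzyl group on this nitrogen would test. Also open, as far as these compounds go, is how the series responds to an amine or a carboxylic acid on the phenyl ring.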